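The compounds below may be only part of what the source reports. "The series", "measured", "known", "first", "only" and "open" are said of these compounds alone.

Two compounds share one core and differ only at a single aromatic carbon. Compound 1 `O=C(O)CCc1ccc(OCc2coc(-c3cccc(F)c3)n2)cc1` gives in a functional assay on CHO cells for agonist activity at Free fatty acid receptor 1 (Homo sapiens), read by FLIPR and calcium flux, in the presence of a further agent that is not named here (on this read-out lower numbers stand for an effect already at smaller amounts and higher numbers for an effect only at larger amounts of compound), a value of 560 nM, and compound 2 `O=C(O)CCc1ccc(OCc2coc(-c3ccccc3)n2)cc1` gives 700 nM in this assay. Compound 2 thus carries the higher of the two numbers, yet the gap is small: a 1.3-fold higher number from compound 1 to compound 2 (0.10 log units; within the scatter), so the two cannot be told apart on this assay. Compound 3 `O=C(O)CCc1ccc(OCc2coc(-c3cccc(Cl)c3)n2)cc1` has not yet been measured and differs from compound 2 by chloro in place of hydrogen on an aromatic carbon. Among the compounds with values here, the one measured step that bears on this change is the exchange of fluoro for hydrogen on an aromatic carbon, a 1.3-fold higher number from compound 1 to compound 2 (0.10 log units; within the scatter), which stayed within the scatter. A halogen entering at that carbon is therefore expected to move the number only modestly, if at all, perhaps toward a slightly lower value. The expected step in this assay is a 1.7-fold lower number from compound 2 to compound 3 (0.22 log units; within the scatter). Compound 3 is estimated at 420 nM, with a range from 180 nM to 1000 nM.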

Compound 3, half-maximal effective concentration: 160 nM
Compound 3: middle estimate off by 2.6-fold (0.42 log units), on the high side, outside the stated range (below it).
By their numbers in this assay, from the lowest: compound 3; then compounds 1 and 2 (each within the scatter of the next).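

In this assay the aromatic carbon that showed no readable response to fluoro does respond to chloro, with a 4.4-fold lower number from compound 2 to compound 3 (0.64 log units; beyond the scatter) for the change from phenyl to 3-chlorophenyl. The two halogens are also not interchangeable at this carbon: putting chloro in place of fluoro gives a 3.5-fold lower number from compound 1 to compound 3 (0.54 log units; beyond the scatter) and so a difference that the pair of fluoro and hydrogen did not show. Nothing available here explains why chloro and fluoro part ways at this carbon.

As far as these compounds go, whether bromo, methyl or trifluoromethyl at the same carbon would lower the number further, match chloro or lose the gain remains open. So does whether chloro would give a similar step on a different carbon of that ring, or whether the step belongs to this one carbon alone.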